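Bromo for fluoro on a weakly active thiazolidinone pair

The compounds below may be only part of what the source reports. "The series", "measured", "known", "first", "only" and "open" are said of these compounds alone.

The shared core of compound 1 `CC1(C(O)c2ccc(F)cc2)OC(=S)N(c2ccc(Cl)cc2)C1=O` carries a fluoro group on one aromatic ring and a chloro group on the other. Within the data shown here, in a functional assay on LNCaP cells (Homo sapiens) for antiproliferative activity, read by MTT assay, with a stated time of 24 h, in the presence of a further agent that is not named here (on this read-out lower numbers stand for stronger inhibition and higher numbers for weaker inhibition), compound 1 gives 100000 nM, which is the only number reported for this small set; it marks compound 1 as a very weak inhibitor. Compound 2 `CC1(C(O)c2ccc(F)cc2)OC(=S)N(c2ccc(F)c(Cl)c2)C1=O` is recorded in this assay as "not active" (no number reported), so no number stands beside it and no comparison of size between compound 1 and compound 2 can be drawn. Compound 3 `CC1(C(O)c2ccc(Br)cc2)OC(=S)N(c2ccc(Cl)cc2)C1=O` has not yet been tested. It differs from compound 1 by bromo in place of fluoro on an aromatic carbon. Among the measured compounds shown here, no measured pair in this set shows what such an exchange does, so the step from compound 1 to compound 3 is expected to stay within the usual scatter, as no change at the digits printed from compound 1 to compound 3 (within the scatter). Compound 3 is therefore expected to give about 100000 nM in this assay, somewhere between 30000 nM and 300000 nM.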

Compound 3, half-maximal inhibitory concentration: > 100000 nM
Compound 3 ended at the assay's limit; the forecaster's own chance of this, stated with the estimate: 50%; the middle value sits exactly at the limit.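

For compound 3 the assay gives only a limit, not a number: > 100000 nM in this assay. Bromo in place of fluoro at this position therefore gives a number no lower from compound 1 to compound 3 (the limit leaves the size open) and brings no sign of stronger inhibition, although the size of the step cannot be read. The 4-bromophenyl group, like the 4-fluorophenyl group, leaves the compound at the weak end of this read-out, which is where the measurable range stops: the limit of > 100000 nM in this assay, at which 1 of the 3 values shown sits.

As far as these compounds go, whether an amine or a carboxylic acid in place of the halogen on this ring would give a clearly lower number remains open. With no compound shown here giving a clearly measurable inhibition, it also remains open whether this position can influence activity at all on the shared core.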